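Series notes: methyl in place of 4-fluorophenyl, compound 2 to 4

The source may hold more compounds than are shown below. What is called first, only, known or untested is meant among the compounds shown, and "the series" means these compounds.

Three compounds have been run in an assay on isolated protein for binding affinity to sphingosine 1-phosphate receptor 2 (Homo sapiens), read by surface plasmon resonance; on this read-out lower numbers stand for tighter binding and higher numbers for weaker binding. Compound 1 `Cn1nc(C(F)(F)F)c2c(-c3ccccc3)cc(NNC(=O)Nc3cc(Cl)nc(Cl)c3)nc21` gives 940 nM, compound 2 `Cc1nn(C)c2nc(NNC(=O)Nc3cc(Cl)nc(Cl)c3)cc(-c3ccc(F)cc3)c12` gives 980 nM, and compound 3 `COc1ccc(-c2cc(NNC(=O)Nc3cc(Cl)nc(OC)c3)nc3c2cnn3C)cc1` gives 1980 nM. Compound 2 holds the second highest of the three numbers. Its nearest neighbour is compound 1, within the scatter, so no order between those two can be read; its furthest is compound 3, beyond the scatter, which is the only separation among the three that carries weight. For the measured compounds named here, no pair of measured compounds differs in a single place, so no measured step within the shared core is at hand.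

Compound 4 `Cc1cc(NNC(=O)Nc2cc(Cl)nc(Cl)c2)nc2c1c(C)nn2C` has not yet been measured in this assay. It differs from compound 2 as follows: methyl in place of 4-fluorophenyl on an aromatic carbon. The measured compounds vary elsewhere and say nothing about a change at this place. A move toward weaker binding is nonetheless expected, and the step from compound 2 is estimated at a 3.1-fold higher number from compound 2 to compound 4 (0.49 log units; beyond the scatter). Compound 4 is expected to give 3000 nM, within a range of 1000 nM to 10000 nM.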

Compound 4, dissociation constant: 11000 nM
Compound 4: middle estimate off by 3.7-fold (0.56 log units), on the low side; measured number outside the range, above it.
By their numbers in this assay, from the lowest: compounds 1 and 2 (each within the scatter of the next); then compound 3; then compound 4.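

For the compounds shown here, at this aromatic carbon, opposite the ring nitrogen, the substituent matters strongly in this assay: methyl in place of 4-fluorophenyl gives an 11-fold higher number from compound 2 to compound 4 (1.05 log units; beyond the scatter), the first measured step at this position and a large one. The six-membered aromatic ring therefore cannot be swapped for methyl here without a marked move toward weaker binding, at least in this single pair on the core of compound 2. Nothing at hand explains the size of this step.

Still open, on these data alone, is whether the aromatic ring, the fluorine or simply the larger group accounts for the step, a question that a plain phenyl, an ethyl or a cyclopropyl on the core of compound 2 could help separate. Also open, as far as these compounds go, is whether a pyridyl ring would hold the binding of compound 2, and whether the same step appears on the cores of compound 1 and compound 3.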